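A few compounds are considered here, and "the series" means these few. Any claim that something is new, unique, unknown or untested is made for them only; others in the source may bear on it.

In a functional assay (a lower number here means a stronger inhibitor, a higher number a weaker inhibitor), compound 1 (`CC(C)=CCOc1ccc2c(c1)OC(c1ccccc1F)CC2=O`) gives 6360 nM, compound 2 (`CC(C)=CCOc1ccc2c(c1)OC(c1ccc(Cl)cc1)CC2=O`) gives 6970 nM and compound 3 (`CC(C)=CCOc1cc(O)c2c(c1)OC(c1ccccc1F)CC2=O`) gives 5300 nM, so compound 3 is not separated from the other two. Compound 4 (`CC(C)=CCOc1cc(O)c2c(c1)OC(c1ccccc1Br)CC2=O`) carries bromo in place of fluoro on an aromatic carbon, ortho to a large group (bromo in place of fluoro on an aromatic carbon). Going by the values given here, no measured step makes this exact exchange. The closest is a 1.1-fold higher number from compound 1 to compound 2 (0.04 log units; within the scatter), with 4-chlorophenyl in place of 2-fluorophenyl, while a 1.2-fold lower number from compound 1 to compound 3 (0.08 log units; within the scatter) adds only the hydroxy. Neither step leaves the scatter, so no step beyond the scatter is expected in this assay. The estimated step is a 1.0-fold higher number from compound 3 to compound 4 (0.02 log units; within the scatter). For compound 4 the expected value is 5500 nM, with an estimated range of 2500 nM to 12000 nM.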

Compound 4, half-maximal inhibitory concentration: 3820 nM
Compound 4: middle estimate off by 1.4-fold (0.16 log units), on the high side; the range from low to high includes it.
By their numbers in this assay, from the lowest: compounds 4, 3, 1 and 2 (each within the scatter of the next).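

In this assay, going by these compounds alone, the first direct exchange at this position, 2-bromophenyl in place of 2-fluorophenyl with the hydroxy present, gives a step within the scatter (a 1.4-fold lower number from compound 3 to compound 4 (0.14 log units; within the scatter)). Fluoro and bromo on this aromatic carbon, ortho to a large group, are therefore not separated in this assay. No supporting measurement accompanies this result. From the compounds shown here alone, whether a methoxy group or an amine at this place would move the number beyond the scatter remains open. So does whether the bromo exchange reads the same in the absence of the hydroxy.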